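The source may hold more compounds than are shown below. What is called first, only, known or untested is meant among the compounds shown, and "the series" means these compounds.

Going by the values given here, in a functional assay on L1210 cells (Mus musculus) for antiproliferative activity, with a stated time of 48 h (a higher number here means a weaker inhibitor, a lower number a stronger inhibitor), three compounds have numbers so far. Compound 1 (`C=C(Br)C(=O)Nc1ccc(C(=O)/C=C/c2ccccc2OC)cc1`) gives 1700 nM in this test, compound 2 (`C=C(Br)C(=O)Nc1ccc(C(=O)/C=C/c2ccc(OC)cc2OC)cc1`) gives 520 nM and compound 3 (`COc1ccccc1/C=C/C(=O)c1ccc(N)cc1`) gives 12000 nM as the highest number of the three, which makes it the weakest inhibitor of the set.

Compound 4 (`COc1ccc(/C=C/C(=O)c2ccc(N)cc2)c(OC)c1`) is still unmeasured and differs from compound 3 in one place: methoxy in place of hydrogen on an aromatic carbon describes the change, a methoxy in place of hydrogen on an aromatic carbon, meta to a methoxy group and para to a large group.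

The same replacement has been seen once (a 3.3-fold lower number from compound 1 to compound 2 (0.51 log units; beyond the scatter)), a modest step toward a lower number and beyond the scatter. That step was measured with the (1-bromoethenyl)carbonyl on the nitrogen. Among the compounds with values here, compound 3 lacks this group (a 7.1-fold higher number from compound 1 to compound 3 (0.85 log units; beyond the scatter)), and no methoxy step has been measured without it, so the transfer is uncertain.

On the evidence of compound 2 and its step (a 3.3-fold lower number from compound 1 to compound 2 (0.51 log units; beyond the scatter)), a modest drop of similar size is expected here, and the estimated change is a 3.0-fold lower number from compound 3 to compound 4 (0.48 log units; beyond the scatter) in this assay as the best guess. Compound 4 is thus estimated at 4000 nM as a middle value, with an expected range from 1500 nM to 11000 nM around it.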

Compound 4, half-maximal inhibitory concentration: 34000 nM
Compound 4: the middle estimate sits 8.5-fold (0.93 log units) below what was measured; measured number above the stated range.
By their numbers in this assay, from the lowest: compound 2; then compound 1; then compound 3; then compound 4.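

Without the (1-bromoethenyl)carbonyl on the nitrogen, the methoxy meta to a methoxy group and para to a large group moves the number in this assay upward instead of downward (a 2.8-fold higher number from compound 3 to compound 4 (0.45 log units; beyond the scatter)). Going by these compounds alone, the direction of this replacement therefore differs between the two cores, something the single earlier step could not show: the same change on two cores in this assay, a 3.3-fold lower number (0.51 log units; beyond the scatter) from compound 1 to compound 2 and a 2.8-fold higher number (0.45 log units; beyond the scatter) from compound 3 to compound 4, 9.3-fold (0.97 log units) apart, beyond the scatter of two such steps. Read along the other edge of the same four compounds, taking away the (1-bromoethenyl)carbonyl costs far more when the added methoxy is present (a 65-fold higher number from compound 2 to compound 4 (1.82 log units; beyond the scatter)), so the two changes do not act independently of each other in this set: the same change on two cores in this assay, a 7.1-fold higher number (0.85 log units; beyond the scatter) from compound 1 to compound 3 and a 65-fold higher number (1.82 log units; beyond the scatter) from compound 2 to compound 4, 9.3-fold (0.97 log units) apart, beyond the scatter of two such steps.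

The compounds shown leave open whether this reversal needs the (1-bromoethenyl)carbonyl itself or would appear with any acyl group on that nitrogen, such as an acetyl or a chloroacetyl group. They also leave open whether the effect at this place is particular to methoxy, which a hydroxy, an ethoxy or a fluoro group there on both cores would help to settle.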